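A few compounds are considered here, and "the series" means these few. Any claim that something is new, unique, unknown or untested is made for them only; others in the source may bear on it.

In a functional assay on HT-29 cells (Homo sapiens) for cytotoxicity, read by MTT assay, with a stated time of 72 h (on this read-out lower numbers stand for stronger inhibition and higher numbers for weaker inhibition), compound 1 (`Cc1ccc(NC(=O)CN2CCN(c3nnc(Cc4ccncc4)c4ccccc34)CC2)c(C)c1`) gives 1930 nM and compound 2 (`O=C(CN1CCN(c2nnc(Cc3ccncc3)c3ccccc23)CC1)Nc1ccc(Br)cc1`) gives 1990 nM, while compound 3 (`O=C(CN1CCN(c2nnc(Cc3ccccc3)c3ccccc23)CC1)Nc1cc(C(F)(F)F)ccc1Cl`) gives 66800 nM, the highest number of the three. Compound 4 (`O=C(CN1CCN(c2nnc(Cc3ccncc3)c3ccccc23)CC1)Nc1cc(C(F)(F)F)ccc1Cl`) differs from compound 3 by pyridin-4-yl in place of phenyl on a saturated chain carbon bound to an aromatic carbon, that is, benzyl to (pyridin-4-yl)methyl on a saturated chain carbon bound to an aromatic carbon.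

Within the data shown here, no measured step isolates this change. Among the measured compounds shown here, the only step available, a 1.0-fold higher number from compound 1 to compound 2 (0.01 log units; within the scatter), lies within the scatter; it concerns the group on an amide-type nitrogen, and both of its compounds carry pyridin-4-yl. Compound 3 differs from compounds 1 and 2 in both places, so its gap to them cannot be assigned to either place. Given the small size of a 1.0-fold higher number from compound 1 to compound 2 (0.01 log units; within the scatter), the group on the nitrogen is provisionally expected to count for little, which would put compound 4 not far from compound 2 at 1990 nM. The estimated change is a large one towards lower numbers, a 17-fold lower number from compound 3 to compound 4 (1.22 log units; beyond the scatter). Part of the gap may still belong to the group on the nitrogen, so the expected range is wider on the upper side. For compound 4 the estimate is 4000 nM, with an expected range of 1200 nM to 25000 nM.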

Compound 4, half-maximal inhibitory concentration: 4810 nM
Compound 4: middle estimate off by 1.2-fold (0.08 log units), on the low side; measured number inside the range.
By their numbers in this assay, from the lowest: compounds 1 and 2 (each within the scatter of the next); then compound 4; then compound 3.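

In this assay the step of a 14-fold lower number from compound 3 to compound 4 (1.14 log units; beyond the scatter) isolates pyridin-4-yl in place of phenyl on a saturated chain carbon bound to an aromatic carbon, with the 2-chloro-5-(trifluoromethyl)phenyl group unchanged, and this change is large. The group on the amide-type nitrogen, which made no difference between compound 1 and compound 2, now has a modest effect: a 2.4-fold higher number from compound 2 to compound 4 (0.38 log units; beyond the scatter) and a 2.5-fold higher number from compound 1 to compound 4 (0.40 log units; beyond the scatter) both lie beyond the scatter. No evidence at hand explains either result.

Among these compounds, still open is whether the large step from phenyl to pyridin-4-yl carries over to other groups on the amide-type nitrogen, as the phenyl side appears here with only one such group. Also open, as far as these compounds go, is how pyridin-3-yl or a longer chain would behave at the position bearing pyridin-4-yl.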